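A few compounds are considered here, and "the series" means these few. Any claim that something is new, unique, unknown or untested is made for them only; others in the source may bear on it.

Three compounds built on a shared core, each carrying a chain that ends in an ((iodomethyl)carbonyl)amino group, were tested in an assay on isolated protein for inhibition of hexokinase-1 (Rattus norvegicus), with a stated time of 6 h, tested at 10 mM; on this read-out higher numbers stand for more inhibition at the one concentration tested (going by the name of the read-out) and lower numbers for less inhibition. Compound 1 `O=C(CI)NCCCCCCCCNc1ncnc2c1ncn2[C@@H]1O[C@H](COP(=O)(O)OP(=O)(O)OP(=O)(O)O)[C@@H](O)[C@H]1O` gives 35%. Compound 2 `O=C(CI)NCCCCC(=O)NCCCCCCNc1ncnc2c1ncn2[C@@H]1O[C@H](COP(=O)(O)OP(=O)(O)OP(=O)(O)O)[C@@H](O)[C@H]1O` gives 0%, and compound 3 `O=C(CI)NCCCCCC(=O)NCCCNc1ncnc2c1ncn2[C@@H]1O[C@H](COP(=O)(O)OP(=O)(O)OP(=O)(O)O)[C@@H](O)[C@H]1O` gives 0%. Compound 2 thus stands level with compound 3 at the digits shown, and together they are the lowest of the three numbers, while its one measured step, a number 35 percentage points lower from compound 1 to compound 2 (beyond the scatter), lies beyond the scatter.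

Compound 4 `O=C(CI)NCCC(=O)NCCCCCCNc1ncnc2c1ncn2[C@@H]1O[C@H](COP(=O)(O)OP(=O)(O)OP(=O)(O)O)[C@@H](O)[C@H]1O` has not yet been measured. It differs from compound 2 in one place: ((iodomethyl)carbonyl)amino in place of 2-(((iodomethyl)carbonyl)amino)ethyl on a saturated chain carbon, two bonds along the chain from a carbonyl carbon. Among the measured compounds shown here, no measured step makes this same exchange, so the expectation rests on the surroundings only. For the measured compounds named here, the single step seen, a number 35 percentage points lower from compound 1 to compound 2 (beyond the scatter), took the read-out down to the lowest number of the set, and compound 3, which also carries two carbonyl groups in its chain, gives 0% as well. Since both such compounds give that same low number, compound 4 is expected to give it too. For compound 4 the estimated step is a number 3 percentage points higher from compound 2 to compound 4 (within the scatter), nothing beyond the scatter. Compound 4 is therefore estimated at 3%, with a range from 0% to 15%.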

Compound 4, a percentage reported as inhibition, at one concentration (the size of the read-out at that concentration, not a potency): 0%
For compound 4 the middle estimate is 3 percentage points above the measured one, within the range that was stated.
By their numbers in this assay, from the lowest: compounds 2, 3 and 4 (each within the scatter of the next); then compound 1.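

In this assay, the exchange of 2-(((iodomethyl)carbonyl)amino)ethyl for ((iodomethyl)carbonyl)amino on a saturated chain carbon, two bonds along the chain from a carbonyl carbon, gives no change at the digits printed from compound 2 to compound 4 (within the scatter), so shortening the chain at this position does not restore any read-out. The step of a number 35 percentage points lower from compound 1 to compound 4 (beyond the scatter) shows that the drop seen with compound 2 also appears with a group of 10 heavy atoms, and so is not tied to the group of 12 heavy atoms alone. No supporting data bear on why these chains read as they do.

With compound 2 and compound 4 both at the bottom of the scale, this exchange can only be read as no change. On these data alone, whether a longer all-carbon chain, or an amine or a carboxylic acid in place of the ((iodomethyl)carbonyl)amino group, would read differently remains open.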